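Swapping Chloro for Fluoro in Two Related Compounds

A few compounds are considered here, and "the series" means these few. Any claim that something is new, unique, unknown or untested is made for them only; others in the source may bear on it.

Compound 1, compound 2 and compound 3 have been measured in an ADME assay on cells (Macrophage, Mus musculus) for cytotoxicity, read by resazurin assay, with a stated time of 3 days; on this read-out higher numbers stand for weaker inhibition and lower numbers for stronger inhibition. Compound 1 `O=C(Nc1cc(C(F)(F)F)ccc1Cl)c1cc(Cl)ccc1O` gives 3500 nM. Compound 2 `O=C(Nc1cc(C(F)(F)F)ccc1F)c1cc(Cl)ccc1O` differs from compound 1 by fluoro in place of chloro on an aromatic carbon. In this assay compound 2 gives 2600 nM. The step recorded for this change is a 1.3-fold lower number from compound 1 to compound 2 (0.13 log units; within the scatter). Compound 3 `O=C(Nc1ccc(F)c(Cl)c1)c1cc(Cl)ccc1O` gives 4400 nM in this assay . The difference between the core of compound 1 and the core of compound 3 is not broken down here.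

Compound 4 `O=C(Nc1ccc(F)c(F)c1)c1cc(Cl)ccc1O` has not yet been measured in this assay . It differs from compound 3 by fluoro in place of chloro on an aromatic carbon. Going by the values given here, this is the same kind of change as the one from compound 1 to compound 2, but not the same: in compound 1 the chloro group sits ortho to a large group and para to a trifluoromethyl group, whereas in compound 3 it sits ortho to a fluoro group and meta to a large group.

For compound 4 the expected step from compound 3 is a 1.3-fold lower number from compound 3 to compound 4 (0.10 log units; within the scatter), set beside the measured 1.3-fold lower number from compound 1 to compound 2 (0.13 log units; within the scatter). This expectation rests on the measured step from compound 1 to compound 2 lying within the scatter, so the number for compound 4 is estimated to stay close to that of compound 3. Compound 4 is therefore estimated to give 3500 nM in this assay , with a range from 1700 nM to 7500 nM.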

Compound 4, half-maximal inhibitory concentration: 7700 nM
Compound 4: the middle estimate sits 2.2-fold (0.34 log units) below what was measured; measured number outside the range, above it.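

In this assay, fluoro in place of chloro on the core of compound 3 gives a 1.8-fold higher number from compound 3 to compound 4 (0.24 log units; within the scatter), a step that cannot be told apart from repeat measurement on its own. Set beside the same change on the other core, the earlier step points the other way on paper, yet the gap between the two does not go beyond what two such steps can show by chance: the same change on two cores in this assay, a 1.3-fold lower number (0.13 log units; within the scatter) from compound 1 to compound 2 and a 1.8-fold higher number (0.24 log units; within the scatter) from compound 3 to compound 4, 2.4-fold (0.37 log units) apart, within the scatter of two such steps. This shows that, across these two pairs, the change has no measurable effect on this read-out that could be told from scatter, but it does not show that the change would carry over unaltered to a further core, nor that the two cores truly respond in opposite directions, since two pairs whose steps both lie within the scatter can settle neither point.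

The compounds shown leave open whether a different group on this aromatic carbon, such as a nitrile, a methoxy group or an amine, would give a step that stands clear of the scatter. They also leave open whether fluoro in place of chloro reads the same way in any other assay.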